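Shifting a Methyl Around a Fused Ring

The source may report more compounds than this note shows. Statements on the series, on what has been measured and on what is new or still open speak of the compounds shown alone.

For the measured compounds named here, compound 1, `Oc1ccc(-c2cc3ccccc3o2)cc1`, gives 24% in a physicochemical assay, read by spectrophotometry, with a stated time of 1 min, tested at 100 uM (on this read-out lower numbers stand for less inhibition and higher numbers for more inhibition at the one concentration tested (going by the name of the read-out)), the lowest of the two numbers measured so far; compound 2, `Cc1ccc2oc(-c3ccc(O)cc3)cc2c1`, gives 31%. Going by the values given here, the one measured step, a number 7 percentage points higher from compound 1 to compound 2 (within the scatter), also came from a methyl in place of hydrogen on an aromatic carbon and stayed within the scatter. Compound 3, `Cc1cccc2cc(-c3ccc(O)cc3)oc12`, differs from compound 1 by methyl in place of hydrogen on an aromatic carbon. Because the step of a number 7 percentage points higher from compound 1 to compound 2 (within the scatter) was small, a change of a number 4 percentage points higher from compound 1 to compound 3 (within the scatter) is expected, again within the scatter. Compound 3 is therefore estimated at 28%, between 15% and 42%.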

Compound 3, a percentage reported as inhibition, at one concentration (the size of the read-out at that concentration, not a potency): 72%
The estimate for compound 3 lay 44 percentage points below the measured number; the whole stated range lies below it.
By their numbers in this assay, from the lowest: compounds 1 and 2 (each within the scatter of the next); then compound 3.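

In this assay, methyl in place of hydrogen gives a number 48 percentage points higher from compound 1 to compound 3 (beyond the scatter) when it sits ortho to a fused ring and meta to a fused ring, while the same swap at the place seen in compound 2 gives a number 7 percentage points higher from compound 1 to compound 2 (within the scatter) and no more. The effect of this small group therefore depends on where it stands on the core, not merely on its presence. Nothing available explains this difference.

Going by these compounds, whether a larger ethyl or a methoxy group at the compound 3 position would keep, raise or lower the number remains open. So does whether a chlorine atom there would behave like the methyl.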